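The compounds below may be only part of what the source reports. "The series", "measured", "known", "first", "only" and "open" are said of these compounds alone.

Compound 2 `COc1ccc2nc(C)cc(OCC(=O)Nc3ccc(C)cc3)c2c1` and compound 1 `COc1ccc2nc(C)cc(OCC(=O)Nc3ccc(Cl)cc3)c2c1` share one core and differ only by chloro in place of methyl on an aromatic carbon. In an ADME assay on HepG2 cells (Homo sapiens) for cytotoxicity, read by trypan blue exclusion, with a stated time of 48 h, in the presence of a further agent that is not named here (on this read-out higher numbers stand for lower toxicity in this test and lower numbers for higher toxicity in this test), compound 1 gives 89900 nM. For compound 2 this assay reports only a limit of the test, > 149000 nM, as noted in the limit of > 149000 nM in this assay, at which 1 of the 3 values shown sits. The step between them is an at least 1.6-fold lower number from compound 2 to compound 1 (0.21 log units; that floor lies within the scatter). Compound 3 `COc1ccccc1NC(=O)COc1cc(C)nc2ccc(C)cc12` holds the same atoms as compound 2 joined differently; the difference between the two cores is not broken down here. For compound 3 this assay again reports only a limit, > 74000 nM, as noted in the limit of > 74000 nM in this assay, at which 1 of the 3 values shown sits. Compound 4 `COc1ccccc1NC(=O)COc1cc(C)nc2ccc(Cl)cc12` is not yet measured. It differs from compound 3 by chloro in place of methyl on an aromatic carbon, the same kind of change as that from compound 2 to compound 1 but not the same: here the aromatic carbon is part of a fused or bridged system of two rings, meta to a fused ring and para to a fused ring, whereas earlier it was para to a large group. Resting on the measured step of an at least 1.6-fold lower number from compound 2 to compound 1 (0.21 log units; that floor lies within the scatter), the expected step is an at least 1.0-fold lower number from compound 3 to compound 4 (0.02 log units; that floor lies within the scatter). Compound 4 is therefore expected to give about 70000 nM in this assay, estimated between 30000 nM and 150000 nM.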

Compound 4, half-maximal cytotoxic concentration: 140000 nM
The estimate for compound 4 lay 2.0-fold (0.30 log units) below the measured number; the range from low to high includes it.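

In this assay, going by these compounds alone, compound 3 is reported only as a limit, so no step from compound 3 to compound 4 can be read: the limit of > 74000 nM in this assay, at which 1 of the 4 values shown sits.
The compounds shown leave open how large the change from methyl to chloro is between compound 3 and compound 4, and whether it runs the same way as between compound 2 and compound 1.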